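The source may hold more compounds than are shown below. What is called first, only, known or untested is meant among the compounds shown, and "the series" means these compounds.

Compound 1, `NC(=S)NNc1ncnc2c1cnn2-c1ccccc1`, gives in an ADME assay on cells (Peritoneal macrophage, Mus musculus, strain Swiss) for cytotoxicity, read by MTT assay, with a stated time of 48 h (a higher number here means that more compound is tolerated, a lower number that less compound is tolerated), only an assay limit, > 200000 nM. Compound 2, `NC(=S)NNc1ncnc2c1cnn2-c1ccc(F)cc1`, likewise gives in this assay only a limit, > 200000 nM. The step that the two limits leave unreadable from compound 1 to compound 2 therefore cannot be sized, because of the limit of > 200000 nM in this assay, at which 2 of the 2 values shown sit. Compound 3, `NC(=S)NNc1ncnc2c1cnn2-c1ccc(Cl)cc1`, differs from compound 2 by chloro in place of fluoro on an aromatic carbon. Among the measured compounds shown here, the only measured step is unreadable, so no direction or size beyond the scatter is indicated for this change. Compound 3 is therefore expected to remain near the same limit, a step of a number no higher from compound 2 to compound 3 (the limit leaves the size open). For compound 3 the estimated value is 200000 nM, with a range from 100000 nM to 400000 nM.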

Compound 3, concentration lethal to 50% of the cells: > 200000 nM
Compound 3: a limit, no number; the forecaster's own chance of this, stated with the estimate: 80%; the middle value lies on the limit itself.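

Compound 1, compound 2 and compound 3 all give only an assay limit, so no step among them can be read: the limit of > 200000 nM in this assay, at which 3 of the 3 values shown sit.

The compounds shown leave open whether hydrogen, fluoro or chloro at this place makes any difference in this assay.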